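This account rests on a few compounds, and the source may have more. Where it says the series, first, only, none or still open, it means among the compounds named here.

Measured compounds:
- compound 1, `O=C(Nc1ccc(Oc2ccc(-c3nccs3)cc2)cc1)Nc1ccc(F)c(Cl)c1`: 43.9%
- compound 2, `O=C(Nc1ccc(Oc2ccc(-c3ncc[nH]3)cc2)cc1)Nc1cccc(C(F)(F)F)c1`: 28.1%
- compound 3, `O=C(Nc1ccc(Oc2ccc(-c3ncc[nH]3)cc2)cc1)Nc1cc(C(F)(F)F)ccc1Cl`: 32.3%

In a functional assay on MDA-MB-231 cells (Homo sapiens) for inhibition, read by MTT assay and WST assay, with a stated time of 72 h, tested at 10 uM (a higher number here means more inhibition of growth at the concentration tested, a lower number less inhibition of growth), compound 1 gives 43.9%, compound 2 gives 28.1% and compound 3 gives 32.3%. Compound 3 stands second highest of the three: its nearest neighbour is compound 2, within the scatter, while compound 1 lies beyond the scatter above it. For the measured compounds named here, the only single-point step among the measured compounds is a number 4.2 percentage points higher from compound 2 to compound 3 (within the scatter), which is too small to count as a real change.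

Compound 4, `O=C(Nc1ccc(Oc2ccc(-c3ncc[nH]3)cc2)cc1)Nc1ccc(F)c(Cl)c1`, has not yet been measured. It differs from compound 3 by 3-chloro-4-fluorophenyl in place of 2-chloro-5-(trifluoromethyl)phenyl on an amide-type nitrogen. Going by the values given here, no measured step changes exactly this part of the molecule. Compound 1 carries the same 3-chloro-4-fluorophenyl group as compound 4 but differs from compound 3 in more than one place, so its value only hints at where compound 4 might land. Taking compound 3 as the starting point and compound 1 as an upper guide, compound 4 is expected to give about 37% in this assay, between 22% and 52%, an estimated step of a number 4.7 percentage points higher from compound 3 to compound 4 (within the scatter) that may well stay within the scatter.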

Compound 4, percent growth inhibition at one concentration: 4.2%
For compound 4 the middle estimate is 32.8 percentage points above the measured one; measured number below the stated range.
By their numbers in this assay, from the lowest: compound 4; then compounds 2 and 3 (each within the scatter of the next); then compound 1.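

In this assay the group on the amide-type nitrogen proves able to move the number well beyond the scatter: there is a number 28.1 percentage points lower from compound 3 to compound 4 (beyond the scatter) and a number 23.9 percentage points lower from compound 2 to compound 4 (beyond the scatter) when 3-chloro-4-fluorophenyl enters, whereas the earlier chloro-for-hydrogen step on this ring stayed within the scatter. That group does not bring a low number in every setting, since 1H-imidazol-2-yl in place of 1,3-thiazol-2-yl on an aromatic carbon gives a number 39.7 percentage points lower from compound 1 to compound 4 (beyond the scatter) while 3-chloro-4-fluorophenyl stays fixed, so the outcome here also depends on that other ring. Nothing available gives a reason for these drops.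

As far as these compounds go, it remains open how 1,3-thiazol-2-yl would behave alongside the groups of compound 2 and compound 3. An amine or a carboxylic acid on the ring attached to the amide-type nitrogen also remains to be seen in this series.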